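Chloro to iodo swap: working notes on compounds 1 to 4

This account rests on a few compounds, and the source may have more. Where it says the series, first, only, none or still open, it means among the compounds named here.

Measured so far:
compound 1 `Nc1ccc(-c2nc3ccc(F)cc3s2)cc1I` gives 100 nM
compound 2 `Nc1ccc(-c2nc3ccc(F)cc3s2)cc1Cl` gives 70 nM
compound 3 `Nc1ccc(-c2nc3cc(F)ccc3s2)cc1Cl` is treated in its own sentence below

In a functional assay on OVCAR-5 cells (Homo sapiens) for inhibition (on this read-out higher numbers stand for weaker inhibition of growth and lower numbers for stronger inhibition of growth), compound 1 gives 100 nM and compound 2 gives 70 nM. For the measured compounds named here, the one change between them, (iodo in place of chloro on an aromatic carbon), made a 1.4-fold higher number from compound 2 to compound 1 (0.15 log units; within the scatter). Compound 3 gives < 10 nM, which is a limit of this assay and not a number (the limit of < 10 nM in this assay, at which 1 of the 3 values shown sits). Compound 2 and compound 3 share the same atoms joined differently; the difference between the two cores is not broken down here.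

Compound 4 `Nc1ccc(-c2nc3cc(F)ccc3s2)cc1I` has not been measured in this assay. It differs from compound 3 by iodo in place of chloro on an aromatic carbon, the same change as from compound 2 to compound 1, at a place described in the same words. The step that the limit leaves unreadable from compound 3 to compound 4 is expected to be about as small as a 1.4-fold higher number from compound 2 to compound 1 (0.15 log units; within the scatter), which stayed within the scatter. Because compound 3 stands at a limit (the limit of < 10 nM in this assay, at which 1 of the 3 values shown sits), compound 4 may also be reported only as a limit. Compound 4 is estimated at 8 nM, expected between 2 nM and 30 nM.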

Compound 4, concentration for 50% growth inhibition: 280 nM
For compound 4 the middle estimate is 35-fold (1.54 log units) below the measured one; measured number outside the range, above it.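

In this assay, the change from chloro to iodo did not carry over from one core to the other, as the step on the core of compound 3 is an at least 28-fold higher number from compound 3 to compound 4 (1.44 log units; beyond the scatter), and the two steps do not agree: the same change on two cores in this assay, a 1.4-fold higher number (0.15 log units; within the scatter) from compound 2 to compound 1 and an at least 28-fold higher number (1.44 log units; beyond the scatter) from compound 3 to compound 4, at least 19-fold (1.29 log units) apart, beyond the scatter of two such steps The value of compound 3 is a limit of the assay and not a number: the limit of < 10 nM in this assay, at which 1 of the 4 values shown sits. The two pairs show that, for these compounds, the step measured on one core was a poor guide to the step on the other; they do not show why the cores differ, how large the second step really is, or how the change would behave on any further core.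

Open, as far as these compounds go, is whether the same split between the two cores appears with other groups on that aromatic carbon, such as bromo, methyl or nitrile. Also open, from the compounds shown here alone, is whether it persists when the amino group is replaced, for example by an acetamide.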